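The compounds below may be only part of what the source reports. "The series", "measured", "known", "first", "only" and "open" are said of these compounds alone.

Measured so far:
compound 1 `COc1ccc2nc(C(=O)Nc3ccc(-c4ccccc4)cc3)c(C)c(O)c2c1`: 3.05%
compound 2 `Cc1c(C(=O)Nc2ccc(-c3ccccc3)cc2)nc2ccccc2c1O`: 1.98%
compound 3 `CCc1ccc2nc(C(=O)Nc3c(F)cc(-c4cccc(F)c4)cc3F)c(C)c(C(=O)O)c2c1`: 2.45%

In a functional assay on A-375 cells (Homo sapiens) for antiproliferative activity, read by MTT assay, with a stated time of 24 h, tested at 0.14 ug/mL (a lower number here means a weaker effect, a higher number a stronger effect of the compound at the concentration tested), compound 1 gives the highest of the three numbers, yet compound 3 and compound 2 both sit within the scatter of it, so no order among the three can be read. Among the measured compounds shown here, the single measured step between close neighbours, a number 1.1 percentage points lower from compound 1 to compound 2 (within the scatter), likewise falls within the scatter. Compound 4 `COc1ccc2nc(C(=O)Nc3ccc(-c4ccccc4)cc3)c(C)c(C(=O)O)c2c1` differs from compound 1 by carboxy in place of hydroxy on an aromatic carbon. For the measured compounds named here, no measured step bears directly on this change; compound 3 carries a carboxy group and gives 2.45%, which says only that such a group does not stand out here. For compound 4 a step of a number 0.3 percentage points lower from compound 1 to compound 4 (within the scatter) is expected, that is, none beyond the scatter. Compound 4 is estimated at 2.8%, within 0% to 9%.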

Compound 4, a percentage reported as inhibition, at one concentration (the size of the read-out at that concentration, not a potency): 3.65%
Estimate against measurement, compound 4: 0.9 percentage points below, within the range that was stated.
By their numbers in this assay, from the lowest: compounds 2, 3, 1 and 4 (each within the scatter of the next).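

Carboxy in place of hydroxy on this aromatic carbon, ortho to a methyl group and opposite the ring nitrogen, gives a number 0.6 percentage points higher from compound 1 to compound 4 (within the scatter) in this assay. Among the compounds shown here, this is the first direct reading at this position, and on the core of compound 1 the exchange does not separate the two compounds, even though the entering group has more heavy atoms. No measurement at hand accounts for the result.

From the compounds shown here alone, whether an amine or a methyl ester on this carbon would move the read-out beyond the scatter stays open. So does whether any change here matters at a higher concentration.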